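Compound 4 and a limit shared by three compounds

A few compounds are considered here, and "the series" means these few. Any claim that something is new, unique, unknown or untested is made for them only; others in the source may bear on it.

- compound 1 `CC(C)(C)[C@H]1C(O)=C(C2=C(Cl)S(=O)(=O)c3cc(NS(C)(=O)=O)ccc3N2)C(=O)N1Cc1ccc(F)cc1` gives > 50000 nM
- compound 2 `CC(C)(C)[C@H]1C(O)=C(C2=CS(=O)(=O)c3cc(F)ccc3N2)C(=O)N1Cc1ccc(F)cc1` gives > 50000 nM
- compound 3 `CC(C)(C)[C@H]1C(O)=C(C2=CS(=O)(=O)c3cc(C#N)ccc3N2)C(=O)N1Cc1ccc(F)cc1` gives > 50000 nM

All three readings come from an ADME assay on 2209-23 cells (Homo sapiens) for cytotoxicity, read by WST assay and thymidine incorporation (a higher number here means that more compound is tolerated, a lower number that less compound is tolerated), and each is a limit of the assay, not a number. Compound 1 therefore has no exact position, only its limit of > 50000 nM. The series as measured so far is summed up as the limit of > 50000 nM in this assay, at which 3 of the 3 values shown sit.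

Compound 4 `CC(C)(C)[C@H]1C(O)=C(C2=C(C(N)=O)S(=O)(=O)c3cc(NS(C)(=O)=O)ccc3N2)C(=O)N1Cc1ccc(F)cc1` departs from compound 1 in one place, with carbamoyl in place of chloro on a double-bonded ring carbon, next to the ring sulfur (carbamoyl in place of chloro on a double-bonded ring carbon).

Among the compounds with values here, only one measured step compares two compounds that differ in one place, namely cyano in place of fluoro on an aromatic carbon. That step is a step that the two limits leave unreadable from compound 2 to compound 3. It has no readable size and lies at a different kind of carbon, so it bears on the new change only weakly. Within the data shown here, no measured step covers this exchange of groups.

With no readable step to scale from, no shift beyond the scatter is expected in this assay, in either direction. A report of compound 4 as a limit is considered the most likely outcome. The expected change is a number no higher from compound 1 to compound 4 (the limit leaves the size open). Compound 4 is estimated at 50000 nM, with an expected range from 25000 nM to 100000 nM.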

Compound 4, half-maximal cytotoxic concentration: > 50000 nM
Compound 4 was reported as a limit; the forecaster's own chance of this, stated with the estimate: 85%; the middle value lies on the limit itself.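

Within the data shown here, compound 1 and compound 4 are both reported as limits in this assay, so the exchange of chloro for carbamoyl yields no step that can be read between them. The compounds shown leave open where any of them truly stands, since each gives only the same limit: the limit of > 50000 nM in this assay, at which 4 of the 4 values shown sit.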